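The compounds below may be only part of what the source reports. "The series", "measured", "known", "first", "only" and "open" are said of these compounds alone.

Of the compounds shown here, two sharing one core have been measured. Compound 1 `CN(C)c1ccc(C2CC(c3ccc(-n4ccnc4)cc3)=NN2)cc1` carries a hydrogen on the amine nitrogen in the ring, and in a functional assay on MDA-MB-231 cells (Homo sapiens) for inhibition, read by sulforhodamine B assay, tested at 10 uM (on this read-out higher numbers stand for more inhibition at the one concentration tested (going by the name of the read-out) and lower numbers for less inhibition), compound 1 gives 7.6%. Compound 2 `CN(C)c1ccc(C2CC(c3ccc(-n4ccnc4)cc3)=NN2C(=O)CCCl)cc1` bears a (2-chloroethyl)carbonyl in place of that hydrogen; in this assay compound 2 gives 2.1%. Going by the values given here, the single measured step, a number 5.5 percentage points lower from compound 1 to compound 2 (within the scatter), stays inside the scatter. Compound 2 thus holds the lower of the two numbers, with compound 1 the nearest value, and the gap between them is within the scatter, so neither can be ranked above the other.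

Compound 3 `C=C(C)C(=O)N1N=C(c2ccc(-n3ccnc3)cc2)CC1c1ccc(N(C)C)cc1` differs from compound 2 at the carbonyl carbon: 1-methylethenyl in place of 2-chloroethyl on a carbonyl carbon. Among the compounds with values here, no measured step exchanges one acyl group for another. Within the data shown here, the one step at hand, from hydrogen to (2-chloroethyl)carbonyl, was within the scatter, and it shows only that an acyl group on this nitrogen left the read-out essentially where it was. The step in this assay is therefore expected to be a number 2.9 percentage points higher from compound 2 to compound 3 (within the scatter), nothing beyond the scatter. The estimate for compound 3 in this assay is 5%, between -10% and 20%.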

Compound 3, a percentage reported as inhibition, at one concentration (the size of the read-out at that concentration, not a potency): 4.3%
Compound 3: middle estimate off by 0.7 percentage points, on the high side; low and high end bracket the measured number.
By their numbers in this assay, from the lowest: compounds 2, 3 and 1 (each within the scatter of the next).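

Going by these compounds alone, this is the first exchange of one acyl group for another on the ring nitrogen. In this assay, putting 1-methylethenyl in place of 2-chloroethyl on a carbonyl carbon gives a number 2.2 percentage points higher from compound 2 to compound 3 (within the scatter) and so does not separate a chain holding chlorine from an all-carbon one with a double bond outside aromatic rings. Set against the hydrogen, the new acyl group gives a number 3.3 percentage points lower from compound 1 to compound 3 (within the scatter) and thus, like the (2-chloroethyl)carbonyl group, cannot be told apart from compound 1 on this read-out, which leaves none of the three compounds ranked above another. The data at hand offer nothing that bears on why these numbers lie so close together.

As far as these compounds go, only hydrogen and these two acyl groups appear on this nitrogen, so it stays open whether a longer chain, an amine or a carboxylic acid in the group on the carbonyl carbon would move the number beyond the scatter. From the compounds shown here alone, it also stays open whether a read-out at another concentration would separate these compounds.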